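Aryl swap on the ring nitrogen; liver-cell growth

This account rests on a few compounds, and the source may have more. Where it says the series, first, only, none or still open, it means among the compounds named here.

Compound 2 `N#CC1=C(N)Oc2c(c3nc4ccccc4nc3c3ccccc23)C12C(=O)N(Cc1cnnn1-c1ccccc1Br)c1ccccc12` is measured in an ADME assay on L02 cells (Homo sapiens) for antiproliferative activity, read by MTT assay, with a stated time of 48 h; a lower number here means a stronger inhibitor, a higher number a weaker inhibitor. In this assay compound 2 reaches only the limit > 50000 nM. Its chloro counterpart compound 1 `N#CC1=C(N)Oc2c(c3nc4ccccc4nc3c3ccccc23)C12C(=O)N(Cc1cnnn1-c1ccccc1Cl)c1ccccc12` likewise gives only the limit > 50000 nM in this assay. The step that the two limits leave unreadable from compound 1 to compound 2 therefore cannot be read, as the limit of > 50000 nM in this assay, at which 2 of the 2 values shown sit, shows. Compound 3 `COc1ccc(-n2nncc2CN2C(=O)C3(C(C#N)=C(N)Oc4c3c3nc5ccccc5nc3c3ccccc43)c3ccccc32)cc1` carries 4-methoxyphenyl in place of 2-bromophenyl on an aromatic nitrogen. Among the compounds with values here, no measured step has a readable size, and both measured values sit at the limit, so for compound 3 a value at the limit again is expected, with a step that the limit leaves unreadable from compound 2 to compound 3 not expected to exceed the scatter. Compound 3 is estimated at 80000 nM, within 30000 nM to 300000 nM.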

Compound 3, half-maximal inhibitory concentration: > 50000 nM
Compound 3: no number, only a limit; the forecaster's own chance of this, stated with the estimate: 85%; the middle value lies beyond the limit too.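

In this assay, no step among compound 1, compound 2 and compound 3 can be read: the limit of > 50000 nM in this assay, at which 3 of the 3 values shown sit.

Going by these compounds, whether the aryl group on the aromatic nitrogen changes this read-out at all stays open.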